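This account rests on a few compounds, and the source may have more. Where it says the series, first, only, none or still open, it means among the compounds named here.

Measured so far:
compound 1 `Cn1c(=O)c(S(=O)(=O)c2ccc([N+](=O)[O-])cc2F)cc2cnc(Nc3ccc4[nH]ccc4c3)nc21`: 200 nM
compound 2 `Cn1c(=O)c(S(=O)(=O)Nc2ccc(F)cc2F)cc2cnc(Nc3ccc4[nH]ccc4c3)nc21`: 5000 nM
compound 3 `Cn1c(=O)c(C(=O)Nc2ccc(F)cc2F)cc2cnc(Nc3ccc4[nH]ccc4c3)nc21`: 5000 nM

In a functional assay on K562 cells (Homo sapiens) for inhibition, read by trypan blue exclusion, with a stated time of 72 h (on this read-out higher numbers stand for weaker inhibition and lower numbers for stronger inhibition), compound 3 gives 5000 nM, level at the digits shown with compound 2 and, together with it, the highest of the three numbers; compound 1 sits far lower. The unmeasured compound 4 `Cn1c(=O)c(S(=O)(=O)c2ccc(F)cc2)cc2cnc(Nc3ccc4[nH]ccc4c3)nc21` differs from compound 3 in one place: (4-fluorophenyl)sulfonyl in place of (2,4-difluorophenyl)carbamoyl on an aromatic carbon. Among the compounds with values here, the single measured step that bears on this is the one in which the group on the sulfonyl sulfur was changed from 2-fluoro-4-nitrophenyl to (2,4-difluorophenyl)amino, a 25-fold higher number from compound 1 to compound 2 (1.40 log units; beyond the scatter). Compound 3, with a (2,4-difluorophenyl)carbamoyl group, gives the same number as compound 2, so replacing the sulfonyl linkage of compound 1 by either of the two nitrogen-bearing linkages went with a large rise. Compound 4 brings back a sulfonyl attached directly to an aromatic ring, as in compound 1, though the ring now carries a single fluorine and no nitro group; nothing measured tells how much that change alone matters. A large fall in number from compound 3 is therefore expected, a 10-fold lower number from compound 3 to compound 4 (1.00 log units; beyond the scatter), though not necessarily all the way to compound 1. For compound 4 the estimate in this assay is 500 nM, with a range from 150 nM to 2000 nM.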

Compound 4, half-maximal inhibitory concentration: 200 nM
Compound 4: middle estimate off by 2.5-fold (0.40 log units), on the high side; the range from low to high includes it.
By their numbers in this assay, from the lowest: compounds 1 and 4 (each within the scatter of the next); then compounds 2 and 3 (each within the scatter of the next).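

In this assay, the low number no longer rests on a single compound: putting (4-fluorophenyl)sulfonyl in place of (2,4-difluorophenyl)carbamoyl on this aromatic carbon gives a 25-fold lower number from compound 3 to compound 4 (1.40 log units; beyond the scatter) and, on the sulfonyl sulfur, putting 4-fluorophenyl in place of (2,4-difluorophenyl)amino gives a 25-fold lower number from compound 2 to compound 4 (1.40 log units; beyond the scatter) in the same direction. Exchanging 2-fluoro-4-nitrophenyl for 4-fluorophenyl on that sulfur gives no change at the digits printed from compound 1 to compound 4 (within the scatter) so, in this pair, the nitro group can be absent without a shift beyond the usual scatter, and a phenyl ring joined directly to the sulfonyl is the feature that compound 1 and compound 4 share. Nothing available explains why these two compounds give lower numbers than the compounds with a nitrogen-bearing linkage.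

As far as these compounds go, the phenyl rings on the sulfonyl in these compounds carry only fluorine or nitro, so it remains open how a methoxy group, an amine or a carboxylic acid on that ring would change the number. From the compounds shown here alone, it is also open whether an unsubstituted phenyl ring, or an ethyl chain in place of the ring, would keep the number this low.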